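Swapping methylsulfonyl for fluoro on an indazole-linked phenyl ring

This account rests on a few compounds, and the source may have more. Where it says the series, first, only, none or still open, it means among the compounds named here.

Measured compounds:
compound 1 `C[C@H](Nc1ncnc2[nH]cnc12)c1nn(-c2cccc(S(C)(=O)=O)c2)c2cc(F)ccc12`: 23%
compound 2 `C[C@H](Nc1nc(N)nc(N)c1C#N)c1nn(-c2cccc(S(C)(=O)=O)c2)c2cc(F)ccc12`: 24%
compound 3 `Cc1ccc2c(c1)c([C@H](C)Nc1ncnc3[nH]cnc13)nn2-c1cccnc1`: 18%

In a functional assay on HepG2 cells (Homo sapiens) for inhibition, read by sulforhodamine B assay, with a stated time of 72 h, tested at 10 uM (a lower number here means less inhibition, a higher number more inhibition at the concentration tested (going by the name of the read-out)), compound 1 gives 23%. Its number and those of compound 2 and compound 3 differ only by amounts within the usual scatter, so the three numbers can only be called level with one another. Among the compounds with values here, the one measured step, a number 1 percentage points higher from compound 1 to compound 2 (within the scatter), changes a group on an amine nitrogen and stays within the scatter.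

Compound 4 `C[C@H](Nc1ncnc2[nH]cnc12)c1nn(-c2cccc(F)c2)c2cc(F)ccc12` differs from compound 1 as follows: fluoro in place of methylsulfonyl on an aromatic carbon. Within the data shown here, no measured step touches this ring position, so there is no direct guide. Given that every measured compound sits in a narrow band, the step of a number 3 percentage points lower from compound 1 to compound 4 (within the scatter) is expected to lie within the scatter. Compound 4 is estimated at 20%, with a range from 8% to 34%.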

Compound 4, a percentage reported as inhibition, at one concentration (the size of the read-out at that concentration, not a potency): 33%
Beside the measured number, compound 4's estimate is 13 percentage points below it, and the stated range covers the measured number.
By their numbers in this assay, from the lowest: compounds 3, 1, 2 and 4 (each within the scatter of the next, the first and the last beyond it).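

The swap of methylsulfonyl for fluoro on this aromatic carbon gives a number 10 percentage points higher from compound 1 to compound 4 (within the scatter) in this assay. Within the data shown here, this is the first measured step at this position, and it shows that a single fluorine can replace the four heavy atoms of methylsulfonyl without moving the number beyond the usual scatter. No measurement at hand explains this step.

On these data alone, what an amine or a carboxylic acid would give at this position stays open. So does whether fluoro would give a similar step with the amine-nitrogen group of compound 2.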